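The source may hold more compounds than are shown below. What is called first, only, known or untested is meant among the compounds shown, and "the series" means these compounds.

Three compounds have been measured in a functional assay on CHO-K1 cells for antagonist activity at C-X-C chemokine receptor type 3 (Homo sapiens), read by FLIPR, with a stated time of 10 min, in the presence of a further agent that is not named here; on this read-out lower numbers stand for stronger inhibition and higher numbers for weaker inhibition:

Compound 1, `Cc1nc(C)n(CC(=O)N2CCN(c3sc(C(F)(F)F)nc3-c3nc4c(F)cccc4[nH]3)C[C@H]2C)n1`, gives 3.1 nM.
Compound 2, `Cc1nc(C)n(CC(=O)N2CCN(c3sc(C(F)(F)F)nc3-c3nc4ccc(C5CCOCC5)cc4[nH]3)C[C@H]2C)n1`, gives 3.3 nM.
Compound 3, `C[C@@H]1CN(c2sc(C(F)(F)F)nc2-c2nc3ccccc3[nH]2)CCN1C(=O)Cn1cnc2c1CCN(C)C2`, gives 3.6 nM.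

Compound 2 stands second highest of the three numbers. Its nearest neighbour is compound 1, whose number lies within the scatter of that of compound 2, and its furthest neighbour is compound 3, whose number likewise lies within the scatter. The three values show no separation that can be read as a difference in this assay, even though the three compounds vary in the substitution of the fused ring system and, in compound 3, in the group carried on the amide.

Compound 4, `Cc1nc(C)n(CC(=O)N2CCN(c3sc(C(F)(F)F)nc3-c3nc4ccc(OC5CNC5)cc4[nH]3)C[C@H]2C)n1`, has not yet been measured. It differs from compound 2 in one place: (azetidin-3-yl)oxy in place of oxan-4-yl on an aromatic carbon. For the measured compounds named here, no step between measured compounds covers this kind of exchange, so the expectation rests only on the observation that the three measured variants of the fused ring system all sit close together. Compound 4 is therefore expected to stay near compound 2, with a step of a 1.2-fold higher number from compound 2 to compound 4 (0.08 log units; within the scatter) of no more than the usual scatter in either direction. Compound 4 is estimated at 4 nM in this assay, within a range from 1.5 nM to 12 nM.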

Compound 4, half-maximal inhibitory concentration: 3.8 nM
Beside the measured number, compound 4's estimate is 1.1-fold (0.02 log units) above it; the measured number falls inside the stated range.
By their numbers in this assay, from the lowest: compounds 1, 2, 3 and 4 (each within the scatter of the next).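

In this assay, putting (azetidin-3-yl)oxy in place of oxan-4-yl on this aromatic carbon gives a 1.2-fold higher number from compound 2 to compound 4 (0.06 log units; within the scatter), so the read-out does not tell the two compounds apart. For the compounds shown here, this is the first comparison in the set that isolates a single place, and it shows that this carbon, para to a fused ring, can carry either group with no measurable difference, even though the groups differ in ring size, in the presence of a ring nitrogen and in the hydrogen-bond donor that only (azetidin-3-yl)oxy carries. No measurement is available that would explain why the two compounds read alike.

The compounds shown leave open whether a carboxylic acid, or a longer chain ending in an amine, on this aromatic carbon would also stay within the scatter of compound 2. Going by these compounds alone, they also leave open whether the same exchange would read alike with a different group on the amide, such as the one in compound 3, as this one pair is the only comparison that rests on a single change.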